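This account rests on a few compounds, and the source may have more. Where it says the series, first, only, none or still open, it means among the compounds named here.

Compound 2 `COc1ccc(-c2cc(=O)c3c(OC)cc(OC)cc3n2S(=O)(=O)c2ccc(Cl)cc2)cc1` was tested in a functional assay on KOPN-8 cells (Homo sapiens) for antiproliferative activity, with a stated time of 72 h; on this read-out higher numbers stand for an effect only at larger amounts of compound and lower numbers for an effect already at smaller amounts. In this assay compound 2 gives only a limit, > 34400 nM. Compound 1 `COc1ccc(-c2cc(=O)c3c(OC)cc(OC)cc3n2S(=O)(=O)c2ccc(C=O)cc2)cc1` is the closest measured neighbour, and in this assay compound 1 likewise gives only a limit, > 34400 nM. The step between them is a step that the two limits leave unreadable from compound 1 to compound 2, so that change cannot be read; both values sit at the limit of > 34400 nM in this assay, at which 2 of the 2 values shown sit. Compound 3 `COc1ccc(-c2cc(=O)c3c(OC)cc(OC)cc3n2S(=O)(=O)Cc2ccccc2)cc1` differs from compound 2 by benzyl in place of 4-chlorophenyl on a sulfonyl sulfur. Among the measured compounds shown here, no measured step bears on this change; the one measured step is unreadable. With both measured neighbours at the limit, compound 3 is expected to stay there as well, and the expected step that the limit leaves unreadable from compound 2 to compound 3 means no shift beyond the scatter can be foreseen. Compound 3 is therefore estimated at 40000 nM, with a range from 10000 nM to 150000 nM, and most likely only a limit will be reported.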

Compound 3, half-maximal effective concentration: > 34400 nM
Compound 3: a limit, no number; the forecaster's own chance of this, stated with the estimate: 75%; the middle value does not contradict the limit.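

Among the compounds shown here, compound 1, compound 2 and compound 3 all give only a limit in this assay, so no step among them can be read: the limit of > 34400 nM in this assay, at which 3 of the 3 values shown sit. The compounds shown leave open whether the group on the sulfonyl sulfur matters for this effect at all.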